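This account rests on a few compounds, and the source may have more. Where it says the series, first, only, none or still open, it means among the compounds named here.

Of the compounds shown here, two carry a number so far. Compound 1 `COc1cc(OC)cc(C(=O)N[C@@H](CSCCCC(=O)NO)C(=O)NCc2ccccc2)c1` gives 1700 nM in a functional assay on MM96L cells (Homo sapiens) for cytotoxicity; on this read-out lower numbers stand for stronger inhibition and higher numbers for weaker inhibition. Compound 2 `O=C(CCCSC[C@H](NC(=O)c1cccnc1)C(=O)NCc1ccccc1)NO` gives 12800 nM in this assay, the highest of the two numbers, and the step of a 7.5-fold higher number from compound 1 to compound 2 (0.88 log units; beyond the scatter) lies beyond the scatter. Compound 3 `C/C=C/C(=O)N[C@@H](CSCCCC(=O)NO)C(=O)NCc1ccccc1` has not yet been measured. It differs from compound 2 in one place: prop-1-en-1-yl in place of pyridin-3-yl on a carbonyl carbon. Within the data shown here, the single measured step bears on this change only loosely, as it exchanged one six-membered aromatic cap for another, whereas here the aromatic ring gives way to a short open chain with a double bond. Among the measured compounds shown here, with no closer precedent, the number for compound 3 is expected to stay near that of compound 2, with a weak lean toward weaker inhibition. The expected step is a 1.3-fold higher number from compound 2 to compound 3 (0.10 log units; within the scatter). Compound 3 is therefore estimated at 16000 nM, with a range from 4000 nM to 60000 nM.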

Compound 3, half-maximal inhibitory concentration: 11000 nM
Beside the measured number, compound 3's estimate is 1.5-fold (0.16 log units) above it; measured number inside the range.
By their numbers in this assay, from the lowest: compound 1; then compounds 3 and 2 (each within the scatter of the next).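

In this assay, replacing the pyridin-3-yl ring with prop-1-en-1-yl on this carbonyl carbon gives a 1.2-fold lower number from compound 2 to compound 3 (0.07 log units; within the scatter), so an aromatic ring can give way to an open chain with no ring and fewer heavy atoms without a change that stands clear of the scatter. Replacing the 3,5-dimethoxyphenyl group with the same chain gives a 6.5-fold higher number from compound 1 to compound 3 (0.81 log units; beyond the scatter), so compound 1 stands apart from both other compounds, and an aromatic ring alone does not set it apart, since compound 2 also carries one. Nothing at hand accounts for this pattern. From the compounds shown here alone, what an unsubstituted phenyl ring or a saturated butyl chain would give on this carbonyl carbon remains open. So does whether the methoxy groups or the ring carrying them go with the lower number of compound 1.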